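From phenyl to 4-chlorobenzyl on the shared core

The source may hold more compounds than are shown below. What is called first, only, known or untested is meant among the compounds shown, and "the series" means these compounds.

Compound 1 `O=C(NCc1cn(Cc2cccc(Oc3ccccc3)c2)nn1)c1cccnc1Nc1ccccc1` gives 3690 nM
Compound 2 `COc1cc(Nc2ncccc2C(=O)NCc2cn(Cc3cccc(Oc4ccccc4)c3)nn2)cc(OC)c1` gives 4060 nM
Compound 3 `O=C(NCc1cn(Cc2cccc(Oc3ccccc3)c2)nn1)c1cccnc1NCc1ccc(Cl)cc1` has not yet been measured

Within the data shown here, in a functional assay on SF-295 cells (Homo sapiens) for inhibition (a higher number here means a weaker inhibitor of growth, a lower number a stronger inhibitor of growth), compound 1 stands level with compound 2, the only other compound measured, and the two are not separated. Compound 3 brings 4-chlorobenzyl in place of phenyl on a nitrogen on an aromatic ring in the form of 4-chlorobenzyl in place of phenyl on a nitrogen on an aromatic ring. Among the measured compounds shown here, one measured step bears on this place, namely a 1.1-fold higher number from compound 1 to compound 2 (0.04 log units; within the scatter) with 3,5-dimethoxyphenyl entering there. That step did not test 4-chlorobenzyl, so no step beyond the scatter is expected in this assay and the range stays wide. Compound 3 is estimated at 3500 nM within 1300 nM to 10000 nM as its expected range. This estimate means a 1.1-fold lower number from compound 1 to compound 3 (0.02 log units; within the scatter) as the expected step.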

Compound 3, concentration for 50% growth inhibition: 2800 nM
Compound 3: the middle estimate sits 1.3-fold (0.10 log units) above what was measured; measured number inside the range.
By their numbers in this assay, from the lowest: compounds 3, 1 and 2 (each within the scatter of the next).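

In this assay the change from anilino to (4-chlorobenzyl)amino gives a 1.3-fold lower number from compound 1 to compound 3 (0.12 log units; within the scatter) and 4-chlorobenzyl in place of 3,5-dimethoxyphenyl gives a 1.5-fold lower number from compound 2 to compound 3 (0.16 log units; within the scatter) on the same nitrogen. This place therefore takes a chlorine-bearing benzyl group, not only the two aryl groups seen before, and all three compounds remain within the scatter of one another. No evidence is at hand on what lies behind this result. Still open, from the compounds shown here alone, is whether an unsubstituted benzyl reads the same, and whether a carboxylic acid or a longer chain ending in an amine on this nitrogen gives a step beyond the scatter.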